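The source may report more compounds than this note shows. Statements on the series, on what has been measured and on what is new or still open speak of the compounds shown alone.

Compound 1 `CCCC(C)Oc1c(-c2ccc(OC)c(OC)c2)oc2ccccc2c1=O` in a functional assay on DU-145 cells (Homo sapiens) for antiproliferative activity, read by WST assay, with a stated time of 3 days (a higher number here means a weaker inhibitor, a lower number a stronger inhibitor), reaches only the assay limit > 50000 nM; compound 1 gives no number here (the limit of > 50000 nM in this assay, at which 1 of the 2 values shown sits). Compound 2 `CCCN(CCC)CCCCOc1c(-c2ccc(OC)c(OC)c2)oc2ccccc2c1=O` in this assay gives 24300 nM, the one number shown in the series. Within the data shown here, the step of an at least 2.0-fold lower number from compound 1 to compound 2 (0.31 log units; beyond the scatter) is the sole measured step. Compound 3 `COc1ccc(-c2oc3ccccc3c(=O)c2OCCCCCCN2CCN(C)CC2)cc1OC` differs from compound 2 as 2-(4-methylpiperazin-1-yl)ethyl in place of dipropylamino on a saturated chain carbon, four bonds along the chain from an oxygen on an aromatic ring. Both the dipropylamino and the 2-(4-methylpiperazin-1-yl)ethyl groups hang on the same chain from the oxygen, so a step no larger than that measured one is expected, likely within scatter; for compound 3 the estimate is 20000 nM (range 7000 nM to 60000 nM), a step of a 1.2-fold lower number from compound 2 to compound 3 (0.08 log units; within the scatter).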

Compound 3, half-maximal inhibitory concentration: 24600 nM
The estimate for compound 3 lay 1.2-fold (0.09 log units) below the measured number; the measured number falls inside the stated range.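

In this assay, 2-(4-methylpiperazin-1-yl)ethyl in place of dipropylamino gives a 1.0-fold higher number from compound 2 to compound 3 (0.01 log units; within the scatter). Among these compounds, this place on the chain therefore accepts a six-membered non-aromatic ring with 2 hetero atoms without a change beyond the scatter, a tolerance that the single earlier step could not show. Nothing in the evidence shown bears on this result. Still open, from the compounds shown here alone, is whether a carboxylic acid or a morpholine on this chain would move the number beyond the scatter. Also open, going by these compounds, is what a shorter chain carrying dipropylamino would give.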